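Side-group exchange on the shared core: expectation for compound 4

The source may hold more compounds than are shown below. What is called first, only, known or untested is meant among the compounds shown, and "the series" means these compounds.

For the measured compounds named here, the shared core is held fixed and only one side group varies. In a functional assay on NCI-H23 cells (Homo sapiens) for inhibition, read by sulforhodamine B assay, with a stated time of 48 h (on this read-out lower numbers stand for stronger inhibition of growth and higher numbers for weaker inhibition of growth), compound 1 `Nc1cc(N)c2nc(-c3ccccc3)c(NCc3ccc(Cl)c(Cl)c3)nc2c1` gives 14100 nM. In this assay compound 2 `Nc1cc(N)c2nc(-c3ccccc3)c(Sc3ccc(F)cc3)nc2c1` gives 19100 nM, and compound 3 `Nc1cc(N)c2nc(-c3ccccc3)c(Oc3ccc(F)cc3)nc2c1` gives 20900 nM. Going by the values given here, all three numbers lie within the usual scatter of one another, so compound 3 stands apart from neither; the one single-point step, a 1.1-fold higher number from compound 2 to compound 3 (0.04 log units; within the scatter), is within the scatter. Compound 4 `Nc1cc(N)c2nc(-c3ccccc3)c(NCc3ccc(F)cc3)nc2c1` carries (4-fluorobenzyl)amino in place of 4-fluorophenoxy on an aromatic carbon. Among the compounds with values here, no measured step covers this exchange; compound 1, which differs from compound 3 in more than one place, and compound 3 show numbers within the scatter of each other. The step of a 1.3-fold lower number from compound 3 to compound 4 (0.12 log units; within the scatter) is therefore expected to stay within the scatter. Compound 4 is estimated at 16000 nM, range 7000 nM to 35000 nM.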

Compound 4, concentration for 50% growth inhibition: 2400 nM
Beside the measured number, compound 4's estimate is 6.7-fold (0.82 log units) above it, outside the stated range (below it).
By their numbers in this assay, from the lowest: compound 4; then compounds 1, 2 and 3 (each within the scatter of the next).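

In this assay the linking atom at this position now matters: (4-fluorobenzyl)amino separates from the two directly linked aryl groups (an 8.7-fold lower number from compound 3 to compound 4 (0.94 log units; beyond the scatter); an 8.0-fold lower number from compound 2 to compound 4 (0.90 log units; beyond the scatter)), which showed no such separation from each other. The amino link alone does not set the number, since the aryl ring on the chain also counts (a 5.9-fold lower number from compound 1 to compound 4 (0.77 log units; beyond the scatter)). No measurement shown explains these steps.

Open, on these data alone, is whether unsubstituted benzylamino keeps this level. Also open, as far as these compounds go, is how a longer chain, such as 2-phenylethylamino, behaves.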